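The source may report more compounds than this note shows. Statements on the series, on what has been measured and on what is new or still open speak of the compounds shown alone.

Measured compounds:
Compound 1, `Nc1cc(N)c2nc(-c3ccccc3)c(Sc3ccc(F)cc3)nc2c1`: in a functional assay on 786-0 cells (Homo sapiens) for inhibition, read by sulforhodamine B assay, with a stated time of 48 h (a lower number here means that less compound is tolerated, a higher number that more compound is tolerated), compound 1 gives < 100000 nM, a limit of the assay rather than a number.
Compound 2, `CCOC(=O)[C@H](CCC(=O)O)NC(=O)c1ccc(Oc2nc3cc(N)cc(N)c3nc2-c2ccccc2)cc1`: in this assay compound 2 gives < 50200 nM, also a limit.
Compound 3, `CCOC(=O)[C@H](CCC(=O)O)NC(=O)c1ccc(CNc2nc3cc(N)cc(N)c3nc2-c2ccccc2)cc1`: in this assay compound 3 gives < 100000 nM, also a limit.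

Compound 1 therefore stands at a limit, one it shares with another compound (the limit of < 100000 nM in this assay, at which 2 of the 3 values shown sit), while the remaining value sits at a different limit (the limit of < 50200 nM in this assay, at which 1 of the 3 values shown sits). Going by the values given here, all three values are limits, and no step between measured compounds has been counted. Compound 4, `COc1ccc(Sc2nc3cc(N)cc(N)c3nc2-c2ccccc2)cc1`, differs from compound 1 in one place: methoxy in place of fluoro on an aromatic carbon. Among the compounds with values here, with no measured step to lean on, the expected step that the limit leaves unreadable from compound 1 to compound 4 is none beyond the scatter. Compound 4 is expected to give about 40000 nM, most likely between 8000 nM and 150000 nM, and quite possibly again only a limit.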

Compound 4, concentration lethal to 50% of the cells: 70800 nM
Compound 4: the middle estimate sits 1.8-fold (0.25 log units) below what was measured; the range from low to high includes it.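

The value of compound 1 is only a limit, and the step from it to compound 4 cannot be read. On these data alone, whether methoxy in place of fluoro on an aromatic carbon changes the result in this assay stays open.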